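The source may report more compounds than this note shows. Statements on the series, on what has been measured and on what is new or still open speak of the compounds shown alone.

Measured so far:
- compound 1 `CCOC(=O)c1ccc(Nc2ccnc(SCC(=O)c3ccc([N+](=O)[O-])cc3)n2)cc1`: 41%
- compound 2 `O=C(O)c1ccc(Nc2ccnc(SCC(=O)c3ccc(C(F)(F)F)cc3)n2)cc1`: 32%

In a functional assay on UO-31 cells (Homo sapiens) for inhibition, read by sulforhodamine B assay, with a stated time of 48 h, tested at 10 uM (on this read-out higher numbers stand for more inhibition of growth at the one concentration tested and lower numbers for less inhibition of growth), compound 1 gives 41% and compound 2 gives 32%. Compound 1 has the higher of the two numbers, but its gap to compound 2 lies within the usual scatter of such measurements, so the two cannot be told apart on this evidence. Among the compounds with values here, compound 2 also differs from compound 1 in more than one place, so no single structural step between them can be read off.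

Compound 3 `CCOC(=O)c1ccc(Nc2ccnc(SCC(=O)c3ccc(C#N)cc3)n2)cc1` has not yet been measured. It differs from compound 1 in one place only: cyano in place of nitro on an aromatic carbon. Within the data shown here, no measured pair shows what this kind of exchange does in this assay, so there is no step to lean on. Given that both measured numbers sit close together, the expected step of a number 5 percentage points lower from compound 1 to compound 3 (within the scatter) is small, with no clear direction beyond the scatter. For compound 3 the estimate in this assay is therefore 36%, with a range from 15% to 57%.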

Compound 3, percent growth inhibition at one concentration: 52%
The estimate for compound 3 lay 16 percentage points below the measured number, and the stated range covers the measured number.
By their numbers in this assay, from the lowest: compounds 2 and 1 (each within the scatter of the next); then compound 3.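

In this assay, the exchange of nitro for cyano on an aromatic carbon, para to a large group, gives a number 11 percentage points higher from compound 1 to compound 3 (beyond the scatter), and this is the only step shown so far that isolates a single change. It shows that the nitro group is not required at this position for growth inhibition at the one concentration tested: the 4-cyanophenyl compound keeps the activity and reads higher, even though the entering group has fewer heavy atoms and one hydrogen-bond acceptor where nitro has two. Nothing measured here explains why this exchange raises the number.

From the compounds shown here alone, a single exchange says little about the position as a whole, and whether an amine, an amide or a methoxy group here would read higher or lower remains open, as does whether the step would keep its size if the rest of the molecule changed. Compound 2 differs from both other compounds in more than one place, so the standing of its trifluoromethyl group at this position cannot be read from these numbers.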